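The compounds below may be only part of what the source reports. "The series", "measured", "known", "first", "only" and "open" are said of these compounds alone.

Of the compounds shown here, three on a shared core have been measured in a functional assay on CCRF-CEM/VCR-1000 cells (Homo sapiens) for inhibition; on this read-out lower numbers stand for stronger inhibition and higher numbers for weaker inhibition: compound 1 `OC(COc1ccccc1C(O)CCc1ccccc1)CN1CCN(c2ccc(F)cc2)CC1`, compound 2 `COC(CCc1ccccc1)c1ccccc1OCC(O)CN(C(C)C)C(C)C` and compound 3 `OC(COc1ccccc1C(O)CCc1ccccc1)CN1CCCCC1`. In this assay compound 1 gives 670 nM, compound 2 gives 660 nM and compound 3 gives 1340 nM. Compound 3 thus stands with the highest number of the three; its gap to compound 1 lies within the scatter of the assay, while its gap to compound 2 lies beyond it. Compound 4 `COC(CCc1ccccc1)c1ccccc1OCC(O)CN1CCCCC1` has not yet been measured in this assay. It differs from compound 3 by methyl in place of hydrogen on an oxygen on a saturated carbon; cut one bond further out, the same difference reads hydroxy to methoxy. Among the compounds with values here, no pair of measured compounds isolates this change on its own, as compound 2 carries the methoxy together with a different amine. Compound 4 is expected to show a 1.6-fold lower number from compound 3 to compound 4 (0.20 log units; within the scatter), a step that should be no more than modest in this assay and, if anything, towards a lower number. On this basis compound 4 is estimated at 850 nM, with a plausible range from 350 nM to 2000 nM.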

Compound 4, half-maximal inhibitory concentration: 770 nM
Estimate against measurement, compound 4: 1.1-fold (0.04 log units) above; measured number inside the range.
By their numbers in this assay, from the lowest: compounds 2, 1, 4 and 3 (each within the scatter of the next, the first and the last beyond it).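

In this assay, within the data shown here, the change from hydroxy to methoxy on this saturated carbon gives a 1.7-fold lower number from compound 3 to compound 4 (0.24 log units; within the scatter) with the piperidin-1-yl amine held constant, the first direct reading of this change, and the methyl on the oxygen is tolerated without a step beyond the scatter. Among these compounds, with the methoxy held constant, the change of amine gives a 1.2-fold higher number from compound 2 to compound 4 (0.07 log units; within the scatter) and so does not separate piperidin-1-yl from diisopropylamino in this assay for this pair, a comparison that the earlier compounds did not offer. No independent measurement is available to account for either step. From the compounds shown here alone, whether a larger group on the same oxygen, such as ethyl or benzyl, or an acetyl group in place of the methyl, would keep the number in this range remains open. Also open, going by these compounds, is whether the hydroxy to methoxy step carries over to the amine of compound 1.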